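A few compounds are considered here, and "the series" means these few. Any claim that something is new, unique, unknown or untested is made for them only; others in the source may bear on it.

Compound 1 `CC(C)c1n[nH]c2c(NCc3ccc(-c4ccccn4)cc3)nc(SCCO)nc12` gives 48 nM in a functional assay on HT cells (Homo sapiens) for antiproliferative activity, read by fluorescence, with a stated time of 72 h; on this read-out lower numbers stand for stronger inhibition of growth and higher numbers for weaker inhibition of growth.
Compound 2 `CC(C)c1n[nH]c2c(NCc3ccc(-c4ccccn4)cc3)nc(SCC(O)CN3CCNCC3)nc12` gives 332 nM in this assay.

Of the two compounds measured, compound 2 stands at the highest number, the weaker grower-inhibitor of the pair; the step of a 6.9-fold higher number from compound 1 to compound 2 (0.84 log units; beyond the scatter) separates it from compound 1 and lies beyond the scatter. Compound 3 `CC(C)c1n[nH]c2c(NCc3ccc(-c4ccccn4)cc3)nc(SCC(C)(C)N)nc12` differs from compound 2 in one place: 1-amino-1-methylethyl in place of 1-hydroxy-2-(piperazin-1-yl)ethyl on a saturated chain carbon bound to a sulfur. Within the data shown here, the only measured step that bears on this change is a 6.9-fold higher number from compound 1 to compound 2 (0.84 log units; beyond the scatter), in which attaching the (piperazin-1-yl)methyl group raised the number well beyond the scatter. Compound 3 removes that group, including its six-membered non-aromatic ring, and carries only a 1-amino-1-methylethyl group in its place, so the number is expected to move back toward that of compound 1 rather than stay near compound 2. The expected step is a 3.3-fold lower number from compound 2 to compound 3 (0.52 log units; beyond the scatter). Compound 3 is therefore estimated at 100 nM, with a range from 30 nM to 400 nM.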

Compound 3, concentration for 50% growth inhibition: 85 nM
For compound 3 the middle estimate is 1.2-fold (0.07 log units) above the measured one; low and high end bracket the measured number.
By their numbers in this assay, from the lowest: compounds 1 and 3 (each within the scatter of the next); then compound 2.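

Replacing 1-hydroxy-2-(piperazin-1-yl)ethyl with the smaller, ring-free 1-amino-1-methylethyl on the saturated chain carbon bound to a sulfur gives a 3.9-fold lower number from compound 2 to compound 3 (0.59 log units; beyond the scatter) in this assay, so most of the loss seen with the piperazine group is recovered. Replacing hydroxymethyl with 1-amino-1-methylethyl at this same place gives a 1.8-fold higher number from compound 1 to compound 3 (0.25 log units; within the scatter), so the two groups cannot be told apart here, and a nitrogen on this chain does not by itself raise the number. No measurement shown explains why the piperazine-bearing group stands apart.

From the compounds shown here alone, it remains open whether the higher number depends on the piperazine ring or simply on the length of the chain. A morpholine ring in place of the piperazine, or an unbranched 2-aminoethyl chain, would help separate these possibilities.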